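A few compounds are considered here, and "the series" means these few. Any claim that something is new, unique, unknown or untested is made for them only; others in the source may bear on it.

Compound 1 `CCCOC(=O)c1c(C)coc1-c1ccc2c(CC)cccc2c1OC`: > 10 ug/mL (a limit)
Compound 2 `CCc1cccc2c(OC(C)=O)c(-c3occ(C)c3COC(C)=O)ccc12`: > 10 ug/mL (a limit)

In a functional assay on DU-145 cells (Homo sapiens) for cytotoxicity, read by MTT assay, with a stated time of 72 h (on this read-out lower numbers stand for an effect already at smaller amounts and higher numbers for an effect only at larger amounts of compound), compound 1 gives only a limit, > 10 ug/mL. Among the measured compounds shown here, compound 1 and compound 2 both stand at the limit of > 10 ug/mL in this assay, at which 2 of the 2 values shown sit, so the series has no numeric value yet and no measured step to draw on. Compound 3 `CCc1cccc2c(OC)c(-c3occ(C)c3COCC(F)(F)F)ccc12` differs from compound 1 as follows: (2,2,2-trifluoroethoxy)methyl in place of propoxycarbonyl on an aromatic carbon, with (2,2,2-trifluoroethoxy)methyl in place of propoxycarbonyl on an aromatic carbon. No change beyond the scatter is expected, and the estimated step that the limit leaves unreadable from compound 1 to compound 3 is read in that light. For compound 3 the expected value is 15 ug/mL, with an estimated range of 6 ug/mL to 40 ug/mL.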

Compound 3, concentration for half-maximal effect: 5.7 ug/mL
Compound 3: the middle estimate sits 2.6-fold (0.42 log units) above what was measured; the whole stated range lies above it.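

In this assay, among the compounds shown here, compound 3 gives the first numeric value of the series, 5.7 ug/mL. Putting (2,2,2-trifluoroethoxy)methyl in place of propoxycarbonyl on this aromatic carbon of the five-membered ring gives an at least 1.7-fold lower number from compound 1 to compound 3 (0.24 log units; that floor lies within the scatter). Because compound 1 stands at a limit, the full size of this step cannot be read: the limit of > 10 ug/mL in this assay, at which 2 of the 3 values shown sit.

The compounds shown leave open whether the fluorine atoms or the ether link go with the step; an ethoxymethyl group without fluorine here would separate the two. On these data alone, how an amine or a carboxylic acid would read at this position also remains open.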